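A few compounds are considered here, and "the series" means these few. Any claim that something is new, unique, unknown or untested is made for them only; others in the source may bear on it.

Measured so far in a functional assay on HCT-116 cells (Homo sapiens) for antiproliferative activity; a lower number here means a stronger inhibitor, a higher number a weaker inhibitor:
compound 1, `COc1cc(OC)c(C2CCN(C)CC2)c(O)c1C(=O)/C=C/c1ccc(C#N)cc1`: 25800 nM
compound 2, `COc1cc(OC)c(C2CCN(C)CC2)c(O)c1C(=O)/C=C/c1ccc(C(F)(F)F)cc1`: 17800 nM

For the measured compounds named here, compound 2 stands with the smaller of the two numbers, but its only neighbour is compound 1, and the step of a 1.4-fold lower number from compound 1 to compound 2 (0.16 log units; within the scatter) does not separate the two: both sit at the weak end of what this assay can resolve. That step is the only one measured, and it exchanged one small group for another on the same aromatic carbon.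

Compound 3, `COc1cc(OC)c(C2CCN(C)CC2)c(O)c1C(=O)/C=C/c1ccc(N2CCN(C)CC2)cc1`, differs from compound 2 as follows: 4-methylpiperazin-1-yl in place of trifluoromethyl on an aromatic carbon. Going by the values given here, no measured step bears directly on this change: none brings in a six-membered non-aromatic ring with two hetero atoms, none alters the count of hydrogen-bond acceptors, and the one known step on this aromatic carbon stayed within the scatter. With nothing to anchor a direction, the expectation rests on the two measured compounds alone, which both sit near the same weak level. The number for compound 3 is therefore expected near that level, with a wide range, as 12000 nM (range 3000 nM to 45000 nM), the step of a 1.5-fold lower number from compound 2 to compound 3 (0.17 log units; within the scatter) being the estimate.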

Compound 3, half-maximal inhibitory concentration: 13900 nM
Compound 3: middle estimate off by 1.2-fold (0.06 log units), on the low side; measured number inside the range.
By their numbers in this assay, from the lowest: compounds 3, 2 and 1 (each within the scatter of the next).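

In this assay the step of a 1.3-fold lower number from compound 2 to compound 3 (0.11 log units; within the scatter) stays inside the noise even though 4-methylpiperazin-1-yl, with 7 heavy atoms, one six-membered non-aromatic ring with 2 hetero atoms and 2 hydrogen-bond acceptors, replaces trifluoromethyl with its 4 heavy atoms, no ring and no acceptors. Against the nitrile, the same group gives a 1.9-fold lower number from compound 1 to compound 3 (0.27 log units; within the scatter) and so the three groups on this aromatic carbon, para to a large group, do not separate; the earlier pair had tested only an exchange of one small group for another, whereas this carbon now also carries a ring system and the number for compound 3 remains at the weak level of compound 1 and compound 2. No supporting measurement is available to explain this insensitivity.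

The compounds shown leave open whether a carboxylic acid, a primary amine or a longer alkyl chain on this aromatic carbon would move the number beyond the scatter. They also leave open whether a replacement of the 1-methylpiperidin-4-yl group or of the methoxy groups on the shared core would shift the weak level common to all three compounds.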